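Aryl swap on a bromoacrylamide antiproliferative series

The source may report more compounds than this note shows. Statements on the series, on what has been measured and on what is new or still open speak of the compounds shown alone.

Measured so far:
- compound 1, `CCc1ccc(-c2nn3cc(-c4cccc(N)c4)nc3s2)cc1`: 6000 nM
- compound 2, `C=C(Br)C(=O)Nc1cccc(-c2cn3nc(-c4ccc(F)cc4)sc3n2)c1`: 250 nM
- compound 3, `C=C(Br)C(=O)Nc1cccc(-c2cn3c(-c4ccccc4)csc3n2)c1`: 1300 nM

In a functional assay on L1210 cells (Mus musculus) for inhibition, read by cell counting, with a stated time of 2 days (a lower number here means a stronger inhibitor, a higher number a weaker inhibitor), compound 2 gives 250 nM, the lowest of the three numbers. Compound 3 gives 1300 nM and compound 1 gives 6000 nM, both gaps to compound 2 being beyond the scatter. Compound 4, `C=C(Br)C(=O)Nc1cccc(-c2cn3nc(-c4ccc(OC)c(OC)c4)sc3n2)c1`, has not yet been measured in this assay. It differs from compound 2 in one place: 3,4-dimethoxyphenyl in place of 4-fluorophenyl on an aromatic carbon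

For the measured compounds named here, no pair among the measured compounds isolates this change, so there is no measured step to lean on; compounds 1 and 3 differ from compound 2 in several places at once and only show the spread of the series. The change keeps the ring count and adds two acceptors in the entering 3,4-dimethoxyphenyl. Compound 4 is therefore expected to stay near compound 2, with the step from compound 2 to compound 4 estimated at a 1.6-fold higher number from compound 2 to compound 4 (0.20 log units; within the scatter), at most a modest loss, quite possibly none beyond the scatter. For compound 4 the estimate in this assay is 400 nM, within a range from 120 nM to 1500 nM.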

Compound 4, half-maximal inhibitory concentration: 42 nM
For compound 4 the middle estimate is 9.5-fold (0.98 log units) above the measured one; measured number outside the range, below it.
By their numbers in this assay, from the lowest: compound 4; then compound 2; then compound 3; then compound 1.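

In this assay, the aryl group on the aromatic carbon of the five-membered ring next to the ring sulfur proves to be a position that moves the number: replacing 4-fluorophenyl with 3,4-dimethoxyphenyl gives a 6.0-fold lower number from compound 2 to compound 4 (0.77 log units; beyond the scatter) and so lies clearly outside ordinary assay variation. The earlier compounds shown here offered no isolated step at this position, and this first one shows that the larger entering group, with its 2 hydrogen-bond acceptors, is not merely accepted but goes with a stronger inhibitor. Nothing available gives a measured reason for this gain, so it stands as an observation on this one pair.

This single step cannot separate the contribution of the two methoxy groups from that of losing the fluorine, and a phenyl carrying just one methoxy group, or a hydroxyl, an amine or a longer alkoxy chain in their place, would be needed to draw that apart. It also leaves open whether the same gain would appear without the bromoacrylamide that compound 2 and compound 4 share.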